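Swapping the Ring on the Amine Nitrogen

The source may report more compounds than this note shows. Statements on the series, on what has been measured and on what is new or still open speak of the compounds shown alone.

Measured so far:
Compound 1 `COc1ccc(Nc2nc(SCc3ccc(C(F)(F)F)cc3)nc3ccccc23)cc1`: 16700 nM
Compound 2 `COc1cc(Nc2nc(SCc3ccc(C(F)(F)F)cc3)nc3ccccc23)cc(OC)c1`: > 50000 nM

In a functional assay on PC-3 cells (Homo sapiens) for cytotoxicity, read by MTT assay, with a stated time of 72 h (on this read-out lower numbers stand for stronger inhibition and higher numbers for weaker inhibition), compound 1 gives 16700 nM. For compound 2 this assay reports only a limit, > 50000 nM, not a number. Compound 2 therefore sits at the limit of > 50000 nM in this assay, at which 1 of the 2 values shown sits, the weaker end of what has been measured, and the step of an at least 2.9-fold higher number from compound 1 to compound 2 (0.47 log units; beyond the scatter) shows that changing the ring on this nitrogen can move the number beyond the usual scatter.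

Compound 3 `Fc1ccc(Nc2nc(SCc3ccc(C(F)(F)F)cc3)nc3ccccc23)cc1Cl` differs from compound 2 by 3-chloro-4-fluorophenyl in place of 3,5-dimethoxyphenyl on a nitrogen on an aromatic ring. Going by the values given here, no measured step involves a halogenated ring at this position, so the size of the coming step cannot be read from the data; only the step of an at least 2.9-fold higher number from compound 1 to compound 2 (0.47 log units; beyond the scatter) shows that this position matters. With compound 2 known only as a limit, the estimate for compound 3 is expected to be about 20000 nM, within 5000 nM to 80000 nM. The expected step of an at least 2.5-fold lower number from compound 2 to compound 3 (0.39 log units; beyond the scatter) is uncertain in both size and direction.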

Compound 3, half-maximal inhibitory concentration: 18600 nM
Estimate against measurement, compound 3: 1.1-fold (0.03 log units) above, within the range that was stated.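

Compound 3 shows that a ring carrying chlorine and fluorine can take the place of a methoxy-bearing ring on this nitrogen with no readable change: in this assay, putting 3-chloro-4-fluorophenyl in place of 4-methoxyphenyl gives a 1.1-fold higher number from compound 1 to compound 3 (0.05 log units; within the scatter). Putting the same ring in place of 3,5-dimethoxyphenyl gives an at least 2.6-fold lower number from compound 2 to compound 3 (0.42 log units; beyond the scatter), so among these three rings, 3,5-dimethoxyphenyl alone stands apart. Compound 2 is known only as a limit, and the true size of its steps stays unread: the limit of > 50000 nM in this assay, at which 1 of the 3 values shown sits.

The compounds shown leave open what chlorine or fluorine does alone on this ring, and how a ring bearing an amine or a carboxylic acid would read. They also leave open whether any group on this nitrogen can bring the number well under those of compound 1 and compound 3.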